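A few compounds are considered here, and "the series" means these few. Any claim that something is new, unique, unknown or untested is made for them only; others in the source may bear on it.

Compound 2, with the structure `CCNC(=O)/C=C1\CCc2ccc(F)cc21`, gives 100% in a functional assay on the whole organism with Mus musculus as the target, at a dose of 100 mg/kg by the intraperitoneal route; on this read-out lower numbers stand for less inhibition and higher numbers for more inhibition at the one dose given (going by the name of the read-out). Compound 1, with the structure `CNC(=O)/C=C1\CCc2cc(F)c(F)cc21`, gives 100% in this assay, so the two stand level and together form the highest of the three numbers. Compound 3, with the structure `CCNC(=O)/C=C1\CCc2c(F)cc(F)cc21`, gives 67% in this assay; the step of a number 33 percentage points lower from compound 2 to compound 3 (beyond the scatter), beyond the scatter, came with fluoro in place of hydrogen on an aromatic carbon. Compound 4 has the structure `CCN(C)C(=O)/C=C1\CCc2ccc(F)cc21` and differs from compound 2 by methyl in place of hydrogen on an amide-type nitrogen. No measured step touches an amide-type nitrogen, so nothing shown predicts this change; since compound 2 already gives the highest number this read-out reports, the number can only hold level or fall. Compound 4 is expected to give 75%, between 30% and 100%. This amounts to an expected step of a number 25 percentage points lower from compound 2 to compound 4 (beyond the scatter).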

Compound 4, a percentage reported as inhibition, in the whole organism at one dose (the size of the read-out at that dose, not a potency): 100%
Beside the measured number, compound 4's estimate is 25 percentage points below it, and the stated range covers the measured number.
By their numbers in this assay, from the lowest: compound 3; then compounds 1, 2 and 4 (each within the scatter of the next).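

In this assay methyl in place of the amide hydrogen gives no change at the digits printed from compound 2 to compound 4 (within the scatter) and so shows that, at this one dose, the read-out stays at its top value without the amide hydrogen. With both numbers at the top of a percentage scale, a difference between these compounds could stay hidden. Nothing available explains this result. As far as these compounds go, it remains open whether a longer chain such as propyl on this nitrogen, or a pyrrolidine ring built around it, would hold the number level.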